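The source may report more compounds than this note shows. Statements on the series, on what has been measured and on what is new or still open speak of the compounds shown alone.

Of the compounds shown here, three have so far been measured in a physicochemical assay for lipophilicity, measured as octanol-water partition, at pH 7.4; a lower number here means a more polar compound, a higher number a more lipophilic compound. Compound 3 (`O=C(N[C@H]1CN(S(=O)(=O)c2ccccc2)C[C@@H]1C(=O)N1C[C@H]2CCNC[C@H]21)c1cc(-c2ccccc2Cl)on1`) gives 1.7 in this measurement. Compound 2 (`Cc1ccc2[nH]c(C(=O)N[C@H]3CN(S(=O)(=O)c4ccccc4)CC[C@@H]3C(=O)NCCN(C)C)cc2c1`) gives 1.9 and lies within the usual scatter of compound 3, whereas compound 1 (`Cc1ccc2[nH]c(C(=O)N[C@H]3CCN(S(=O)(=O)C4CC4)C[C@@H]3C(=O)NCCN(C)C)cc2c1`) gives 1 and lies lower than compound 3, beyond that scatter. No two of these compounds differ in one place only, so the set offers no measured step that could serve as a direct guide.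

Compound 4 (`O=CN1CCC[C@H](NC(=O)[C@H]2CN(S(=O)(=O)c3ccccc3)C[C@@H]2NC(=O)c2cc(-c3ccccc3Cl)on2)C1`) has not yet been measured. It differs from compound 3 on a carbonyl carbon, and the change (a group of 9 heavy atoms (6 carbon, 2 nitrogen, 1 oxygen; one six-membered non-aromatic ring with 1 hetero atom) in place of a group of 8 heavy atoms (6 carbon, 2 nitrogen; one four-membered non-aromatic ring with 1 hetero atom, one six-membered non-aromatic ring with 1 hetero atom), on a carbonyl carbon) replaces a group with two rings by one with a single six-membered non-aromatic ring. Among the measured compounds shown here, the step expected in this assay is upward and beyond the scatter, although this expectation rests on the structural change alone and no measured pair tests it. The estimated step is a number 0.90 log units higher from compound 3 to compound 4 (beyond the scatter) and it remains uncertain in size. For compound 4 the estimated value is 2.6 with an expected range from 2 to 3.2 for a single measurement.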

Compound 4, distribution coefficient: 3.1
Beside the measured number, compound 4's estimate is 0.50 log units below it; low and high end bracket the measured number.
By their numbers in this assay, from the lowest: compound 1; then compounds 3 and 2 (each within the scatter of the next); then compound 4.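

In this assay, among the compounds shown here, the first measured step of the set, a number 1.40 log units higher from compound 3 to compound 4 (beyond the scatter), is large and shows that the read-out can move strongly with the group on this carbonyl carbon. The earlier compounds shown here could not show this, as none of them differed in one place only. The change here swaps a group of 8 heavy atoms, with a four-membered and a six-membered non-aromatic ring, for a group of 9 heavy atoms with one six-membered non-aromatic ring, adding an oxygen and a double bond outside aromatic rings while the counts of hydrogen-bond donors and acceptors stay equal, and no measurement at hand speaks to what lies behind the size of this step.

Since ring count, oxygen content and the number of defined stereocentres all change in this single step, the compounds shown leave open which of these differences goes with the rise. They also leave open where other groups on the same carbonyl carbon, such as a morpholine or a chain ending in a carboxylic acid, would fall in this assay, and whether a step of this size would recur on the core of compound 1.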